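This account rests on a few compounds, and the source may have more. Where it says the series, first, only, none or still open, it means among the compounds named here.

Compound 2 `COc1ccc([C@@H]2C(C#N)=C(N)O[C@]3(OC)CCN(C)C[C@@H]23)cc1` stands with the highest number of the two measured in a functional assay on trachea (Cavia porcellus) (a higher number here means a weaker inhibitor, a lower number a stronger inhibitor), at 23100 nM; its nearest neighbour, compound 1 `CO[C@@]12CCN(C)C[C@H]1[C@H](c1ccc(Cl)cc1)C(C#N)=C(N)O2`, gives 10500 nM. That single measured step, a 2.2-fold higher number from compound 1 to compound 2 (0.34 log units; beyond the scatter), is the only one that bears on what follows. Compound 3 `CO[C@@]12CCN(C)C[C@H]1[C@H](c1ccc(N3CCCCC3)cc1)C(C#N)=C(N)O2` differs from compound 2 by piperidin-1-yl in place of methoxy on an aromatic carbon. Going by the values given here, no measured pair shows a piperidin-1-yl group at this place, so the size of the step is uncertain, and a modest change in either direction or none beyond the scatter would fit the one step seen. Compound 3 is therefore expected to give 25000 nM, within 8000 nM to 80000 nM, an estimated step of a 1.1-fold higher number from compound 2 to compound 3 (0.03 log units; within the scatter).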

Compound 3, half-maximal inhibitory concentration: 19000 nM
Compound 3: middle estimate off by 1.3-fold (0.12 log units), on the high side; the range from low to high includes it.
By their numbers in this assay, from the lowest: compounds 1, 3 and 2 (each within the scatter of the next, the first and the last beyond it).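

In this assay, replacing a group of two heavy atoms with piperidin-1-yl, a six-membered non-aromatic ring of six heavy atoms, gives a 1.2-fold lower number from compound 2 to compound 3 (0.08 log units; within the scatter), and replacing chloro gives a 1.8-fold higher number from compound 1 to compound 3 (0.26 log units; within the scatter). This aromatic carbon therefore takes a far larger group, with a ring, without a step beyond the scatter from either earlier compound. Nothing at hand gives a reason for this. Still open, as far as these compounds go, is whether a carboxylic acid or a primary amine on this carbon would give a step beyond the scatter, and whether a longer chain without a ring would behave as piperidin-1-yl does.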